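A thiophen-3-yl amide after two level neighbours

A few compounds are considered here, and "the series" means these few. Any claim that something is new, unique, unknown or untested is made for them only; others in the source may bear on it.

Two amides on one shared core have been measured in a functional assay on SNB-75 cells (Homo sapiens) for inhibition, read by colorimetric assay and sulforhodamine B assay, with a stated time of 48 h (a lower number here means a stronger inhibitor of growth, a higher number a weaker inhibitor of growth), so far. Compound 1 `CCCCCCCCCCCC[C@@H](O)[C@H]1CC[C@H]([C@H](O)CCCCCCCCCCNC(=O)c2ccoc2)O1` carries furan-3-yl on the carbonyl carbon and gives 100000 nM as its value. Compound 2 `CCCCCCCCCCCC[C@@H](O)[C@H]1CC[C@H]([C@H](O)CCCCCCCCCCNC(=O)c2cncs2)O1` carries 1,3-thiazol-5-yl at that place and gives 100000 nM as its value, which leaves it level with compound 1. Among the compounds with values here, the one measured step of no change at the digits printed from compound 1 to compound 2 (within the scatter) is the only guide here, and it is a close parallel, as it too exchanges one five-membered aromatic ring for another on a carbonyl carbon. Compound 3 `CCCCCCCCCCCC[C@@H](O)[C@H]1CC[C@H]([C@H](O)CCCCCCCCCCNC(=O)c2ccsc2)O1` differs from compound 2 only at this place, with thiophen-3-yl in place of 1,3-thiazol-5-yl on a carbonyl carbon and the rest of the structure unchanged. A single step is thin evidence, yet it shows no movement, so no shift beyond the scatter is expected in this assay here. The expected step is no change at the digits printed from compound 2 to compound 3 (within the scatter) on this estimate. Compound 3 is estimated at 100000 nM with an expected range from 40000 nM to 150000 nM in this measurement.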

Compound 3, concentration for 50% growth inhibition: 2820 nM
Estimate against measurement, compound 3: 35-fold (1.55 log units) above; the whole stated range lies above it.
By their numbers in this assay, from the lowest: compound 3; then compounds 1 and 2 (each within the scatter of the next).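

The two level values of compound 1 and compound 2 had made this position look indifferent to the choice of five-membered aromatic ring on the carbonyl carbon, but in this assay thiophen-3-yl in place of 1,3-thiazol-5-yl gives a 35-fold lower number from compound 2 to compound 3 (1.55 log units; beyond the scatter) and so shows that the position does respond to that choice. The same ring in place of furan-3-yl gives a 35-fold lower number from compound 1 to compound 3 (1.55 log units; beyond the scatter) as a second large step, which means that thiophen-3-yl stands apart from both of the other rings and not from just one of them. Sulfur alone does not separate the compounds, for 1,3-thiazol-5-yl carries it too, and the change from that ring to thiophen-3-yl takes out the ring nitrogen and leaves 1 hetero atom in place of 2.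

Going by these compounds, whether thiophen-2-yl, a phenyl ring or a methyl-substituted thiophen-3-yl on the same carbonyl carbon would hold, extend or lose this gain remains open, as does whether it would survive a shorter chain on the shared core. Why the exchange of one ring for another has so large an effect also stays open, since nothing given here bears on it.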